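Swapping the Amide Group on a Shared Core

The source may report more compounds than this note shows. Statements on the series, on what has been measured and on what is new or still open speak of the compounds shown alone.

Compound 2 `Cc1c(C)c2c(c(C)c1O)CCC(C)(C(=O)N1CCCC1)O2` is an amide built on a shared core. In a functional assay (brain) for inhibition, with Rattus norvegicus as the target (a lower number here means a stronger inhibitor, a higher number a weaker inhibitor), compound 2 gives 10000 nM. Compound 1 `Cc1c(C)c2c(c(C)c1O)CCC(C)(C(=O)N1CCNCC1)O2` carries piperazin-1-yl on the same carbonyl carbon, and in this assay compound 1 gives 10000 nM; the step of no change at the digits printed from compound 1 to compound 2 (within the scatter) shows the two readings level. Compound 3 `Cc1c(C)c2c(c(C)c1O)CCC(C)(C(=O)NCc1cccnc1)O2` brings the next change at that carbonyl carbon: ((pyridin-3-yl)methyl)amino in place of pyrrolidin-1-yl on a carbonyl carbon. Among the compounds with values here, the only measured step, no change at the digits printed from compound 1 to compound 2 (within the scatter), also altered the group on this carbonyl carbon and stayed within the scatter. A step of no change at the digits printed from compound 2 to compound 3 (within the scatter) is therefore expected, with no shift beyond the scatter. Compound 3 is estimated at 10000 nM, within 4000 nM to 25000 nM.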

Compound 3, half-maximal inhibitory concentration: 47000 nM
Estimate against measurement, compound 3: 4.7-fold (0.67 log units) below; the whole stated range lies below it.
By their numbers in this assay, from the lowest: compounds 1 and 2 (each within the scatter of the next); then compound 3.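

Replacing pyrrolidin-1-yl with ((pyridin-3-yl)methyl)amino gives a 4.7-fold higher number from compound 2 to compound 3 (0.67 log units; beyond the scatter) and replacing piperazin-1-yl with it gives a 4.7-fold higher number from compound 1 to compound 3 (0.67 log units; beyond the scatter) in this assay so the group on this carbonyl carbon can change the reading, which the two ring amides alone did not show. Compound 3 is the weaker inhibitor in both steps. Nothing available here explains the rise. The compounds shown leave open whether the pyridine ring, the amide hydrogen or the methylene link accounts for it. A benzylamino group, with a plain benzene ring, or a longer chain before the pyridine ring could separate these.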